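Adding a Methoxy to the Phenyl Ring of Compound 2

The compounds below may be only part of what the source reports. "The series", "measured", "known", "first", "only" and "open" are said of these compounds alone.

Among the measured compounds shown here, only two compounds with this shared core have been measured so far in a functional assay on CaEs17 cells (Homo sapiens) for cytotoxicity, read by MTT assay, with a stated time of 72 h; on this read-out higher numbers stand for weaker inhibition and lower numbers for stronger inhibition. Compound 1 `C=C1C(=O)[C@@]23C(=O)OC[C@]4(C(=O)CCC(C)(C)[C@H]4C=O)[C@@H]2CC[C@@H]1[C@H]3OC(=O)CC` gives 1400 nM, and compound 2 `C=C1C(=O)[C@@]23C(=O)OC[C@]4(C(=O)CCC(C)(C)[C@H]4C=O)[C@@H]2CC[C@@H]1[C@H]3OC(=O)c1ccccc1` gives 1710 nM. These values lie within the scatter of each other, so compound 2 cannot be ranked apart from compound 1.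

Compound 3 `C=C1C(=O)[C@@]23C(=O)OC[C@]4(C(=O)CCC(C)(C)[C@H]4C=O)[C@@H]2CC[C@@H]1[C@H]3OC(=O)c1ccc(OC)cc1` differs from compound 2 in one place: methoxy in place of hydrogen on an aromatic carbon. This is methoxy in place of hydrogen on an aromatic carbon, para to a large group, which turns phenyl into 4-methoxyphenyl.

For the measured compounds named here, only one measured step bears on this change, and only indirectly. Placing phenyl in place of ethyl on a carbonyl carbon gave a 1.2-fold higher number from compound 1 to compound 2 (0.09 log units; within the scatter). Going by the values given here, that change sits at the same carbonyl carbon, but no measured compound carries a substituent on the aromatic ring, so the evidence is thin. Among the compounds with values here, with only that small step as a guide, no shift beyond the scatter is expected in this assay. The estimated step is a 1.1-fold lower number from compound 2 to compound 3 (0.03 log units; within the scatter). For compound 3, the expected value is 1600 nM, with an estimated range of 800 nM to 3200 nM.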

Compound 3, half-maximal inhibitory concentration: 2980 nM
Compound 3: middle estimate off by 1.9-fold (0.27 log units), on the low side; the measured number falls inside the stated range.
By their numbers in this assay, from the lowest: compounds 1, 2 and 3 (each within the scatter of the next, the first and the last beyond it).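

Among the compounds shown here, compound 3 is the first compound here with a substituent on the aromatic ring, and in this assay the methoxy step reads as a 1.7-fold higher number from compound 2 to compound 3 (0.24 log units; within the scatter) so at this place, para to a large group, methoxy brings no change that can be told from the usual scatter. For the compounds shown here, measured against the ethyl ester, however, the whole 4-methoxyphenyl group gives a 2.1-fold higher number from compound 1 to compound 3 (0.33 log units; beyond the scatter) and this is the first step to pass beyond the scatter, if only modestly, which the plain phenyl of compound 2 did not do. Two steps that are each too small to read on their own therefore add up to a small gap that can be read.

Nothing available here explains why the number moves with this group. From the compounds shown here alone, it also stays open whether an amine, a carboxylic acid or a chlorine atom at the same place on the ring, or a longer chain in place of the ethyl, would carry the number further from that of compound 1 or bring it back.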